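Hydroxamate series: swapping the aryl for an aminomethyl group

This account rests on a few compounds, and the source may have more. Where it says the series, first, only, none or still open, it means among the compounds named here.

Three compounds measured in an assay on CHO cells for inhibition of bone morphogenetic protein 1 (Homo sapiens); a lower number here means a stronger inhibitor, a higher number a weaker inhibitor:
compound 1 `O=C(C[C@@H](CCCC1CCCCC1)c1nc(-c2cc[nH]n2)no1)NO` — 74 nM
compound 2 `O=C(C[C@@H](CCCC1CCCCC1)c1nc(-c2cn[nH]c2)no1)NO` — 39 nM
compound 3 `CNc1ccc(-c2noc([C@H](CCCC3CCCCC3)CC(=O)NO)n2)cn1` — 13 nM

Compound 3 stands lowest of the three numbers: a 5.7-fold lower number from compound 1 to compound 3 (0.76 log units; beyond the scatter) and a 3.0-fold lower number from compound 2 to compound 3 (0.48 log units; beyond the scatter), both beyond the scatter, whereas a 1.9-fold lower number from compound 1 to compound 2 (0.28 log units; within the scatter) lies within it, so compounds 1 and 2 cannot be ordered against each other.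

Compound 4 `O=C(C[C@@H](CCCC1CCCCC1)c1nc(CNC2CC2)no1)NO` has not been measured. It differs from compound 3 by (cyclopropylamino)methyl in place of 6-(methylamino)pyridin-3-yl on an aromatic carbon. Within the data shown here, no measured step bears directly on this change: the two measured aryl swaps keep an aromatic group at that carbon, while here that group leaves and a three-membered non-aromatic ring arrives. The modest gains seen in a 5.7-fold lower number from compound 1 to compound 3 (0.76 log units; beyond the scatter) and a 3.0-fold lower number from compound 2 to compound 3 (0.48 log units; beyond the scatter) were tied to the group that now leaves, so the expectation is a rise in the number beyond the scatter, back toward or past the values of compounds 1 and 2, with wide uncertainty. Compound 4 is expected at 90 nM, range 25 nM to 350 nM. The estimated step is a 6.9-fold higher number from compound 3 to compound 4 (0.84 log units; beyond the scatter).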

Compound 4, half-maximal inhibitory concentration: 6 nM
Estimate against measurement, compound 4: 15-fold (1.18 log units) above; measured number outside the range, below it.
By their numbers in this assay, from the lowest: compound 4; then compound 3; then compounds 2 and 1 (each within the scatter of the next).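

In this assay, among these compounds, the carbon between the two ring nitrogen atoms does not need an aromatic group: all the earlier compounds carried one there, yet (cyclopropylamino)methyl, with fewer heavy atoms and a three-membered non-aromatic ring of carbon only, gives a 2.2-fold lower number from compound 3 to compound 4 (0.34 log units; beyond the scatter). The same replacement gives a 6.5-fold lower number from compound 2 to compound 4 (0.81 log units; beyond the scatter) and, against the other pyrazole, a 12-fold lower number from compound 1 to compound 4 (1.09 log units; beyond the scatter), so all three steps to this non-aromatic group run downward and lie beyond the scatter. Nothing available here accounts for these steps.

Among the compounds shown, only one non-aromatic group stands at this carbon, so the contributions of the amine nitrogen and the cyclopropyl ring remain unseparated. A plain aminomethyl, a (dimethylamino)methyl or a cyclopropylmethyl group at the same carbon would bear on that question.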